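Working notes: 3,4-dichlorophenyl in place of 4-ethylphenyl

The source may hold more compounds than are shown below. What is called first, only, known or untested is meant among the compounds shown, and "the series" means these compounds.

Three compounds of the series have been run in an ADME assay on HEK293 cells (Homo sapiens) for cytotoxicity, read by resazurin assay, with a stated time of 48 h; on this read-out lower numbers stand for higher toxicity in this test and higher numbers for lower toxicity in this test. Compound 1 `O=S(=O)(Nc1ccc2oc(-c3ccccc3)nc2c1)c1cccc(C(F)(F)F)c1` sits at the limit of the assay, > 100000 nM. Among the compounds with values here, compound 2 `CCc1ccc(S(=O)(=O)Nc2ccc(-c3nc4ccccc4o3)cc2)cc1` gives 82000 nM in this assay, the highest of the two numbers measured so far. Compound 3 `CCc1ccc(S(=O)(=O)Nc2ccc3oc(-c4ccccc4)nc3c2)cc1` gives 81000 nM; the gap between compound 2 and compound 3 lies within the scatter of the test, so the two cannot be told apart. One of the three values is a limit rather than a number (the limit of > 100000 nM in this assay, at which 1 of the 3 values shown sits).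

Compound 4 `O=S(=O)(Nc1ccc(-c2nc3ccccc3o2)cc1)c1ccc(Cl)c(Cl)c1` has not yet been measured. It differs from compound 2 in one place (3,4-dichlorophenyl in place of 4-ethylphenyl on a sulfonyl sulfur). Within the data shown here, no step between measured compounds covers a change of this kind, so its size is uncertain; the expectation is a slight move towards a lower number, probably within the scatter, and not a large shift in either direction. Compound 4 is expected to give 60000 nM in this assay, with a range from 25000 nM to 100000 nM. This corresponds to an expected step of a 1.4-fold lower number from compound 2 to compound 4 (0.14 log units; within the scatter).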

Compound 4, half-maximal cytotoxic concentration: > 100000 nM
Compound 4: no number, only a limit; the forecaster's own chance of this, stated with the estimate: 30%; at least 1.6-fold (0.22 log units) between middle value and limit.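

Compound 4 gives > 100000 nM in this assay, which is a limit of the assay and not a number. The first step read at this position, 3,4-dichlorophenyl in place of 4-ethylphenyl on a sulfonyl sulfur, is an at least 1.2-fold higher number from compound 2 to compound 4 (0.08 log units; that floor lies within the scatter), so this change brings no lower number and no sign of higher toxicity in this test. Its true size cannot be read because the result stops at the end of the read-out: the limit of > 100000 nM in this assay, at which 2 of the 4 values shown sit.

From the compounds shown here alone, it remains open whether the same change would read alike on the core of compound 3, which carries 4-ethylphenyl on a sulfonyl sulfur as well. Also open, going by these compounds, is whether an amine or a carboxylic acid in place of the aryl group on a sulfonyl sulfur would move the number in this assay at all.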